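From a benzylamide terminus to a piperidine amide

This account rests on a few compounds, and the source may have more. Where it says the series, first, only, none or still open, it means among the compounds named here.

Of the compounds shown here, two sharing one core have been tested in an assay on isolated protein for inhibition of thyroid hormone receptor beta (Homo sapiens), read by fluorescence polarization; a lower number here means a stronger inhibitor, a higher number a weaker inhibitor. Compound 1 `CN(Cc1cccc(F)c1)C(=O)CCCNC(=O)c1ccc(S(C)(=O)=O)c([N+](=O)[O-])c1` gives only a limit in this assay, > 60000 nM. Compound 2 `Cc1ccc(N2CCN(C(=O)C3CCN(C(=O)c4ccc(S(C)(=O)=O)c([N+](=O)[O-])c4)CC3)CC2)cc1` likewise returns only a limit in this assay, > 60000 nM. Both values sit at the limit of > 60000 nM in this assay, at which 2 of the 2 values shown sit, so on the numbers shown nothing separates compound 1 from compound 2. The change to compound 3 `CC1CCN(C(=O)CCCNC(=O)c2ccc(S(C)(=O)=O)c([N+](=O)[O-])c2)CC1` is 4-methylpiperidin-1-yl in place of (3-fluorobenzyl)(methyl)amino on a carbonyl carbon whose other neighbours are a saturated chain carbon. Within the data shown here, no measured pair shows a step of this kind, and compound 2, which carries another amide terminus on the same core, also stays at the limit. Compound 3 is therefore expected to remain at the limit, with an estimated step of a number no higher from compound 1 to compound 3 (the limit leaves the size open) of none beyond the scatter. The estimate for compound 3 is 60000 nM, within 30000 nM to 200000 nM.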

Compound 3, half-maximal inhibitory concentration: > 60000 nM
Compound 3: a limit, no number; the forecaster's own chance of this, stated with the estimate: 85%; the middle value sits exactly at the limit.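

Among these compounds, compound 3, like compound 1, returns only a limit in this assay, so no step from compound 1 to compound 3 can be read: the limit of > 60000 nM in this assay, at which 3 of the 3 values shown sit. The compounds shown leave open whether any amide terminus on the shared core can give a measurable inhibition.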